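The source may report more compounds than this note shows. Statements on the series, on what has been measured and on what is new or still open speak of the compounds shown alone.

Compound 1 `COC(=O)/C=C/c1cccc(N(Cc2ccc(/C=C/c3scnc3C)cc2)C(=O)C2CCCCC2)c1` gives 227 nM in an assay on isolated protein with Bile acid receptor (Homo sapiens) as the target; on this read-out lower numbers stand for an effect already at smaller amounts and higher numbers for an effect only at larger amounts of compound.
Compound 2 `COC(=O)/C=C/c1cccc(N(Cc2ccc(C(C)(C)C)cc2)C(=O)C2CCCCC2)c1` reaches only the limit of this assay, reported as > 1000 nM, rather than a number.
Compound 3 `COC/C=C/c1ccc(CN(C(=O)C2CCCCC2)c2cccc(/C=C/C(=O)OC)c2)cc1` gives 233 nM in this assay.

Compound 3 thus stands at the higher of the two numbers actually measured, though its step to compound 1, a 1.0-fold higher number from compound 1 to compound 3 (0.01 log units; within the scatter), lies within the scatter, so the two cannot be told apart. Against compound 2 it shows an at least 4.2-fold lower number from compound 2 to compound 3 (0.63 log units; beyond the scatter), a clear difference, with the size of that step bounded only by the limit (the limit of > 1000 nM in this assay, at which 1 of the 3 values shown sits).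

Compound 4 `COC(=O)/C=C/c1cccc(N(Cc2ccc(-c3ccc(SC)cc3)cc2)C(=O)C2CCCCC2)c1` differs from compound 3 in one place: 4-(methylsulfanyl)phenyl in place of 3-methoxyprop-1-en-1-yl on an aromatic carbon. The measured steps that bear on this are those that swap the group at the same aromatic carbon: an at least 4.4-fold higher number from compound 1 to compound 2 (0.64 log units; beyond the scatter), where a compact tert-butyl replaced a long ethenyl-linked group, and a 1.0-fold higher number from compound 1 to compound 3 (0.01 log units; within the scatter), where one long group replaced another with no change beyond the scatter. The new group is again an extended one, so the expected outcome is a 1.6-fold lower number from compound 3 to compound 4 (0.19 log units; within the scatter), that is, no movement beyond the scatter or a slight gain. Compound 4 is therefore estimated at 150 nM, within a range from 50 nM to 600 nM.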

Compound 4, half-maximal effective concentration: 69 nM
The estimate for compound 4 lay 2.2-fold (0.34 log units) above the measured number; the measured number falls inside the stated range.
By their numbers in this assay, from the lowest: compound 4; then compounds 1 and 3 (each within the scatter of the next). At a limit, above all of these: compound 2.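

Going by these compounds alone, the earlier compounds showed only that two long groups on this aromatic carbon could not be told apart and that both gave a lower number than tert-butyl; in this assay, the 4-(methylsulfanyl)phenyl group now stands apart from both long groups, with a 3.4-fold lower number from compound 3 to compound 4 (0.53 log units; beyond the scatter) and a 3.3-fold lower number from compound 1 to compound 4 (0.52 log units; beyond the scatter). So long groups at this place are not interchangeable, although the result does not show which feature counts: the entering group has a six-membered aromatic ring of carbon only, unlike the 3-methoxyprop-1-en-1-yl it replaces, yet compound 1 also carries a ring and goes against any simple rule that a ring alone is enough. Against tert-butyl the change is large, an at least 14-fold lower number from compound 2 to compound 4 (1.16 log units; beyond the scatter), but compound 2 stands at a limit rather than a number: the limit of > 1000 nM in this assay, at which 1 of the 4 values shown sits.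

The compounds shown do not separate the benzene ring from the methylsulfanyl group on it, so the result for a plain phenyl or a 4-methoxyphenyl at this place remains open. They also leave open whether the gain would hold with a carboxylic acid in place of the methyl ester, which all four compounds share.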